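Replacing thiophen-2-yl with phenyl in a growth inhibitor

The source may report more compounds than this note shows. Statements on the series, on what has been measured and on what is new or still open speak of the compounds shown alone.

Among the compounds with values here, in a functional assay on THP-1 cells (Homo sapiens) for inhibition, read by sulforhodamine B assay, with a stated time of 48 h, tested at 50 uM (a higher number here means more inhibition of growth at the concentration tested, a lower number less inhibition of growth), compound 1 (`COc1cc(/C=C/C(=O)/C=C/c2cccs2)ccc1OCc1cn(CCOc2cc(=O)oc3ccccc23)nn1`) gives 76% and stands highest of the three numbers so far. Compound 2 (`COc1ccc(/C=C/C(=O)/C=C/c2ccc(OCc3cn(CCCCCOc4cc(=O)oc5ccccc45)nn3)c(OC)c2)cc1`) gives 39% and compound 3 (`COc1ccccc1/C=C/C(=O)/C=C/c1ccc(OCc2cn(CCCCOc3cc(=O)oc4ccccc34)nn2)c(OC)c1`) gives 40% in the same test. Both gaps to compound 1 lie beyond the usual scatter, but compounds 2 and 3 differ from it in more than one place.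

Compound 4 (`COc1cc(/C=C/C(=O)/C=C/c2ccccc2)ccc1OCc1cn(CCOc2cc(=O)oc3ccccc23)nn1`) has not yet been measured. It carries phenyl in place of thiophen-2-yl on a double-bonded chain carbon bound to a double-bonded chain carbon. Within the data shown here, no measured pair differs in one place only, so the data give no direct size for such a step. Since the rest of compound 1 stays unchanged, a modest fall is expected, close to the edge of the scatter and smaller than those two gaps. The expected step is a number 11 percentage points lower from compound 1 to compound 4 (beyond the scatter) in this assay by this estimate. For compound 4 the estimated value is 65% with an expected range from 45% to 83% as the likely span.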

Compound 4, percent growth inhibition at one concentration: 61%
Beside the measured number, compound 4's estimate is 4 percentage points above it; the measured number falls inside the stated range.
By their numbers in this assay, from the lowest: compounds 2 and 3 (each within the scatter of the next); then compound 4; then compound 1.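

In this assay, within the data shown here, the swap of thiophen-2-yl for phenyl on a double-bonded chain carbon bound to a double-bonded chain carbon gives a number 15 percentage points lower from compound 1 to compound 4 (beyond the scatter), the first change at this position that can be read on its own. The place therefore responds to this change, yet the thiophen-2-yl group is not needed for growth inhibition here, since compound 4 , with its six-membered aromatic ring of carbon only, still gives 61% in this test. Nothing available explains the size of this step.

The compounds shown leave open how furan-2-yl or pyridin-2-yl would fare at this place. They also leave open whether the same swap gives a similar step when the rest of the molecule carries a longer chain.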